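Swapping a Ring Substituent on a TRPV1 Antagonist Core

The source may report more compounds than this note shows. Statements on the series, on what has been measured and on what is new or still open speak of the compounds shown alone.

Measured compounds:
compound 1 `CCCCNc1nc(C(F)(F)F)ccc1CNC(=O)C(C)c1ccc(NS(C)(=O)=O)c(F)c1` 293 nM
compound 2 `CC(C(=O)NCc1ccc(C(F)(F)F)nc1N1CC=CCC1)c1ccc(NS(C)(=O)=O)c(F)c1` 12.1 nM
compound 3 `CC(C(=O)NCc1ccc(C(F)(F)F)nc1N1CCC(C(=O)c2ccc(F)cc2)CC1)c1ccc(NS(C)(=O)=O)c(F)c1` 990 nM

In a functional assay on CHO-K1 cells for antagonist activity at transient receptor potential cation channel subfamily V member 1 (Homo sapiens), read by FLIPR (a lower number here means a stronger inhibitor, a higher number a weaker inhibitor), compound 3 gives 990 nM, the weakest of the three; its steps to compound 1 and compound 2 both lie beyond the scatter. Compound 4 `CC(C(=O)NCc1ccc(C(F)(F)F)nc1N1CCC(OC(=O)C(C)(C)C)CC1)c1ccc(NS(C)(=O)=O)c(F)c1` differs from compound 3 in one place: ((tert-butyl)carbonyl)oxy in place of (4-fluorophenyl)carbonyl on a saturated ring carbon. For the measured compounds named here, only one measured step exists, a 24-fold lower number from compound 1 to compound 2 (1.38 log units; beyond the scatter), and it concerns the group on the aromatic carbon, not the saturated ring carbon changed here, so it bears on the new step only indirectly. Compound 3 and compound 2 together show that a large group on this ring carbon goes with a weaker number. Compound 4 keeps a large group there, so a modest change is expected, a 1.7-fold lower number from compound 3 to compound 4 (0.22 log units; within the scatter), with compound 4 estimated at 600 nM (range 150 nM to 2500 nM).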

Compound 4, half-maximal inhibitory concentration: 45.2 nM
For compound 4 the middle estimate is 13-fold (1.12 log units) above the measured one, and the stated range ends above it.
By their numbers in this assay, from the lowest: compound 2; then compound 4; then compound 1; then compound 3.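

In this assay, ((tert-butyl)carbonyl)oxy in place of (4-fluorophenyl)carbonyl gives a 22-fold lower number from compound 3 to compound 4 (1.34 log units; beyond the scatter), so a large group on this saturated ring carbon does not by itself go with a weak number. The identity of the group matters here, not only its presence. No measurement shown explains this difference.

Still open, as far as these compounds go, is which part of the change counts: the loss of the aromatic ring, the added oxygen or the tert-butyl. A benzoyloxy group or a simple hydroxyl on the same carbon would help separate these.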